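The source may report more compounds than this note shows. Statements on the series, on what has been measured and on what is new or still open speak of the compounds shown alone.

Compound 1 `O=C(O[C@H]1C[C@H](n2cc(F)c(=O)[nH]c2=O)O[C@@H]1COP(=O)(O)Oc1ccccc1)c1ccccc1` gives 6880 nM in a functional assay on T47D cells (Homo sapiens) for cytotoxicity, read by MTT assay, with a stated time of 48 h; on this read-out lower numbers stand for stronger inhibition and higher numbers for weaker inhibition. Among the compounds with values here, compound 2 `O=C(O[C@H]1C[C@H](n2cc(F)c(=O)[nH]c2=O)O[C@@H]1COP(=O)(O)Oc1cccnc1)c1ccccc1` gives 14400 nM, the highest of the two numbers measured so far; the step of a 2.1-fold higher number from compound 1 to compound 2 (0.32 log units; beyond the scatter) came with pyridin-3-yl in place of phenyl on an oxygen. Compound 3 `C[n+]1cccc(OP(=O)([O-])OC[C@H]2O[C@@H](n3cc(F)c(=O)[nH]c3=O)C[C@@H]2OC(=O)c2ccccc2)c1` carries a group of 11 heavy atoms (6 carbon, 1 nitrogen, 3 oxygen, 1 phosphorus; one six-membered aromatic ring with 1 hetero atom) in place of a group of 10 heavy atoms (5 carbon, 1 nitrogen, 3 oxygen, 1 phosphorus; one six-membered aromatic ring with 1 hetero atom), on an oxygen on a saturated carbon. Within the data shown here, no measured step touches this change: the only step known, from compound 1 to compound 2, concerns a different group at the same oxygen and was modest, and the present change keeps the ring. The number for compound 3 is expected to stay near that of compound 2, with the expected step of a 1.3-fold higher number from compound 2 to compound 3 (0.10 log units; within the scatter) not beyond the scatter, at an estimated 18000 nM within 6000 nM to 50000 nM.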

Compound 3, half-maximal inhibitory concentration: 3910 nM
Compound 3: the middle estimate sits 4.6-fold (0.66 log units) above what was measured, outside the stated range (below it).
By their numbers in this assay, from the lowest: compounds 3 and 1 (each within the scatter of the next); then compound 2.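

In this assay, the oxygen on a saturated carbon tolerates a change that keeps the ring, and the group of 11 heavy atoms gives a 3.7-fold lower number from compound 2 to compound 3 (0.57 log units; beyond the scatter). Against the phenyl-bearing group, the same group gives a 1.8-fold lower number from compound 1 to compound 3 (0.25 log units; within the scatter), so the rise seen with pyridin-3-yl is not retained in compound 3. No data shown here account for either step. Still open, going by these compounds, is whether an ethyl group or a longer chain in place of the added carbon would keep this number. Also open, on these data alone, is whether an amine on the ring would do so.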